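Replacing the tertiary amine side chain in compound 1

A few compounds are considered here, and "the series" means these few. Any claim that something is new, unique, unknown or untested is made for them only; others in the source may bear on it.

Measured compounds in a physicochemical assay for lipophilicity; a higher number here means a more lipophilic compound, a lower number a more polar compound:
- compound 1 `CCN(CC)CCN(C)c1ccc(Cn2c(=O)[nH]c3c(N)nc(C(F)(F)F)cc32)cn1`: 1.3
- compound 2 `Nc1nc(C(F)(F)F)cc2c1[nH]c(=O)n2Cc1ccc(NCCO)nc1`: 1.6
- compound 3 `Nc1nc(C(F)(F)F)cc2c1[nH]c(=O)n2Cc1ccc(NCc2ccccc2)nc1`: 1.8

Compound 1 has the lowest of the three numbers; compound 2 sits a number 0.30 log units higher from compound 1 to compound 2 (within the scatter), and compound 3 sits a number 0.50 log units higher from compound 1 to compound 3 (beyond the scatter). Between the latter two the gap is a number 0.20 log units higher from compound 2 to compound 3 (within the scatter).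

Compound 4 `CN(C)CCNc1ccc(Cn2c(=O)[nH]c3c(N)nc(C(F)(F)F)cc32)cn1` is not yet measured. It differs from compound 1 as follows: (2-(dimethylamino)ethyl)amino in place of (2-(diethylamino)ethyl)(methyl)amino on an aromatic carbon. Both measured steps from compound 1 replaced the same group with a smaller amine and gave modest rises, but neither kept a basic ethylenediamine side chain, so they bear only loosely on this change. With fewer carbons and a new hydrogen-bond donor, a small downward step is expected, a number 0.40 log units lower from compound 1 to compound 4 (beyond the scatter). Compound 4 is therefore estimated at 0.9, within the range 0.5 to 1.3.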

Compound 4, distribution coefficient: 0.7
Beside the measured number, compound 4's estimate is 0.20 log units above it; measured number inside the range.
By their numbers in this assay, from the lowest: compound 4; then compounds 1, 2 and 3 (each within the scatter of the next, the first and the last beyond it).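

In this assay this position also allows a downward move: the change gives a number 0.60 log units lower from compound 1 to compound 4 (beyond the scatter), whereas the other side chains stand higher still, with a number 1.10 log units lower from compound 3 to compound 4 (beyond the scatter) and a number 0.90 log units lower from compound 2 to compound 4 (beyond the scatter). Compound 4 therefore has the lowest number of the four compounds. No measured evidence on hand gives a cause for these steps.

As far as these compounds go, compound 1 and compound 4 differ in both the dimethylamino versus diethylamino group and the methyl on the nitrogen, so the share of each stays open. Also open, from the compounds shown here alone, is how a morpholine or a carboxylic acid on this chain would read in this assay.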